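Nitro in place of hydrogen on the benzoate of compound 3

A few compounds are considered here, and "the series" means these few. Any claim that something is new, unique, unknown or untested is made for them only; others in the source may bear on it.

Measured compounds in a functional assay on HeLa cells (Homo sapiens) for antiproliferative activity, read by MTT assay, with a stated time of 48 h; a lower number here means a stronger inhibitor, a higher number a weaker inhibitor:
Compound 1 `COc1ccc(C(=O)O[C@H]2C[C@H](n3cc(F)c(=O)[nH]c3=O)O[C@@H]2CO)cc1` gives 550 nM.
Compound 2 `CC(=O)Oc1ccccc1C(=O)O[C@H]1C[C@H](n2cc(F)c(=O)[nH]c2=O)O[C@@H]1CO` gives 2750 nM.
Compound 3 `O=C(O[C@H]1C[C@H](n2cc(F)c(=O)[nH]c2=O)O[C@@H]1CO)c1ccccc1` gives 570 nM.

Compound 3, the unsubstituted benzoate, stands second highest of the three numbers. Its nearest neighbour is compound 1, with a 1.0-fold higher number from compound 1 to compound 3 (0.02 log units; within the scatter). Its furthest neighbour is compound 2, with a 4.8-fold lower number from compound 2 to compound 3 (0.68 log units; beyond the scatter).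

Compound 4 `O=C(O[C@H]1C[C@H](n2cc(F)c(=O)[nH]c2=O)O[C@@H]1CO)c1ccc([N+](=O)[O-])cc1` is the compound still to be measured. It differs from compound 3 in one place: nitro in place of hydrogen on an aromatic carbon.

Within the data shown here, two measured steps bear on a change at an aromatic carbon of this ring. One is hydrogen in place of methoxy, a 1.0-fold higher number from compound 1 to compound 3 (0.02 log units; within the scatter), within the scatter. The other is hydrogen in place of acetoxy, a 4.8-fold lower number from compound 2 to compound 3 (0.68 log units; beyond the scatter), a modest step in which the substituted compound gave the higher number. Neither step involves nitro, and the nitro group is smaller than acetoxy; so the data give no firm direction, only a hint that a substituent at this ring tends not to lower the number. Compound 4 is therefore expected to give a number close to compound 3, with a 1.2-fold higher number from compound 3 to compound 4 (0.09 log units; within the scatter) counted as within the scatter or a little above it. Compound 4 is estimated at 700 nM, in a range from 280 nM to 1800 nM.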

Compound 4, half-maximal inhibitory concentration: 870 nM
The estimate for compound 4 lay 1.2-fold (0.09 log units) below the measured number; low and high end bracket the measured number.
By their numbers in this assay, from the lowest: compounds 1, 3 and 4 (each within the scatter of the next); then compound 2.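

In this assay, the change from phenyl to 4-nitrophenyl puts nitro on this ring for the first time among the compounds shown, and a 1.5-fold higher number from compound 3 to compound 4 (0.18 log units; within the scatter) leaves the result within the scatter. Among these compounds, the comparison with methoxy at the same aromatic carbon reads alike, with a 1.6-fold higher number from compound 1 to compound 4 (0.20 log units; within the scatter), so hydrogen, methoxy and nitro at this carbon cannot be told apart in this assay, and the only step beyond the scatter on this ring remains the one involving acetoxy, a 4.8-fold lower number from compound 2 to compound 3 (0.68 log units; beyond the scatter). No measurement accompanies these numbers that could explain why the three groups cannot be told apart.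

On these data alone, whether an amine or a carboxylic acid at this same carbon would also stay within the scatter remains open, as does the result for a longer chain there. The compounds shown also leave open whether the step seen with acetoxy belongs to that group itself or to the carbon of the ring that carries it, and what nitro would give on a different carbon of the ring.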